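Pyrimidin-2-yl Replaces a Dimethylaminopropyl Chain on Compound 2

The compounds below may be only part of what the source reports. "The series", "measured", "known", "first", "only" and "open" are said of these compounds alone.

Measured compounds:
Compound 1 `Cc1cccc2sc(NC(=O)CCN3CCN(CCN(C)C)CC3)nc12` gives 1000 nM in an assay on membranes from brain for displacement of a labelled ligand from Sigma non-opioid intracellular receptor 1 (Cavia porcellus), read by scintillation counting, with a stated time of 120 min; on this read-out higher numbers stand for weaker inhibition and lower numbers for stronger inhibition.
Compound 2 `Cc1cccc2sc(NC(=O)CCN3CCN(CCCN(C)C)CC3)nc12` gives 570 nM in this assay.
Compound 3 `Cc1cccc2sc(NC(=O)CCN3CCN(c4ccccn4)CC3)nc12` gives 1000 nM in this assay.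

The three compounds share one core and differ only in the group on the amine nitrogen of the six-membered non-aromatic ring. Compound 2 has the lowest of the three numbers, but its nearest neighbour is compound 1 at a 1.8-fold lower number from compound 1 to compound 2 (0.24 log units; within the scatter) and its furthest is compound 3 at a 1.8-fold higher number from compound 2 to compound 3 (0.24 log units; within the scatter), so all three sit within the scatter of one another and none can be called the strongest.

Compound 4 `Cc1cccc2sc(NC(=O)CCN3CCN(c4ncccn4)CC3)nc12` is the next member. Relative to compound 2 the change is pyrimidin-2-yl in place of 3-(dimethylamino)propyl on an amine nitrogen in a ring. Going by the values given here, the steps that bear on it are those that also swap a dimethylamino-bearing chain for a six-membered aromatic ring on the same nitrogen: no change at the digits printed from compound 1 to compound 3 (within the scatter) and a 1.8-fold higher number from compound 2 to compound 3 (0.24 log units; within the scatter), both within the scatter. Compound 4 is therefore expected to show a 1.9-fold higher number from compound 2 to compound 4 (0.29 log units; within the scatter), with no change beyond the scatter, leaning if anything toward a slightly higher number as compound 3 did. The estimate for compound 4 in this assay is 1100 nM, within a range of 450 nM to 2700 nM.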

Compound 4, inhibition constant: 505 nM
The estimate for compound 4 lay 2.2-fold (0.34 log units) above the measured number; measured number inside the range.
By their numbers in this assay, from the lowest: compounds 4, 2, 1 and 3 (each within the scatter of the next).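

On the amine nitrogen of the six-membered non-aromatic ring, compound 4 brings the first change within the aromatic group itself, and in this assay the step from pyridin-2-yl to pyrimidin-2-yl reads a 2.0-fold lower number from compound 3 to compound 4 (0.30 log units; within the scatter). Compound 4 also extends the comparison with the chains ending in dimethylamino, with a 1.1-fold lower number from compound 2 to compound 4 (0.05 log units; within the scatter) against the 3-(dimethylamino)propyl chain and a 2.0-fold lower number from compound 1 to compound 4 (0.30 log units; within the scatter) against the 2-(dimethylamino)ethyl chain, so none of the four groups at this position can be separated from another, whether it is an open chain or an aromatic ring. No measurement is available that would account for this lack of separation, or for any of these small steps.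

The compounds shown leave open whether any group on this nitrogen can move the number beyond the scatter, for example a plain phenyl ring, a benzyl group, a carboxylic acid or a chain longer than 3-(dimethylamino)propyl. They also leave open whether pyrimidin-2-yl would behave the same way if the methyl group on the shared core were replaced by a chlorine atom or a methoxy group.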